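This account rests on a few compounds, and the source may have more. Where it says the series, first, only, none or still open, it means among the compounds named here.

Measured compounds:
Compound 1, `Cc1ccc2c(=O)cc(/C=C/[S+](C)[O-])oc2c1`: 7000 nM
Compound 2, `CC(C)COc1ccc2oc(/C=C/[S+](C)[O-])cc(=O)c2c1`: 5000 nM
Compound 3, `Cc1ccc2oc(/C=C/[S+](C)[O-])cc(=O)c2c1`: 7000 nM

In a functional assay on DLD-1 cells (Homo sapiens) for cytotoxicity, with a stated time of 48 h (a higher number here means a weaker inhibitor, a lower number a stronger inhibitor), the three numbers for compound 1, compound 2 and compound 3 all lie within the usual scatter of one another, so compound 2 cannot be set apart from the other two as a stronger or weaker inhibitor; its number simply sits alongside theirs.

Compound 4, `C[S+]([O-])/C=C/c1cc(=O)c2cc(C#N)ccc2o1`, has not yet been measured. It differs from compound 2 in one place: cyano in place of isobutoxy on an aromatic carbon.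

Among the compounds with values here, only one measured step speaks to a swap at this position on the shared core, namely a 1.4-fold higher number from compound 2 to compound 3 (0.15 log units; within the scatter). That swap replaced the same isobutoxy group, and the number did not move beyond the scatter. Nothing measured here involves a cyano group, so no direction can be taken from the data beyond that single step.

The expected step is therefore small, a 1.2-fold higher number from compound 2 to compound 4 (0.08 log units; within the scatter), with no shift beyond the scatter expected in this assay. Compound 4 is expected to give about 6000 nM, within a range from 2500 nM to 15000 nM.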

Compound 4, half-maximal inhibitory concentration: > 10000 nM
Compound 4: no number, only a limit (the forecaster's own chance of this, stated with the estimate: 5%); middle value at least 1.6-fold (0.22 log units) from the limit.
By their numbers in this assay, from the lowest: compounds 2, 1 and 3 (each within the scatter of the next). At a limit, above all of these: compound 4.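

In this assay compound 4 gives > 10000 nM, which is a limit of the assay and not a number. Compound 2 and compound 3, with isobutoxy and methyl on this aromatic carbon, could not be told apart, but cyano here gives the first result without a measured number, and the change can be read only as a floor: an at least 2.0-fold higher number from compound 2 to compound 4 (0.30 log units; that floor lies within the scatter) and an at least 1.4-fold higher number from compound 3 to compound 4 (0.15 log units; that floor lies within the scatter). Since both floors lie within the scatter, the change to cyano may be small or large, and its true size cannot be read: the limit of > 10000 nM in this assay, at which 1 of the 4 values shown sits.

Going by these compounds, whether a longer alkoxy chain, an amine or a carboxylic acid on this aromatic carbon would give a value near those of compound 2 and compound 3 stays open. With only one nitrile shown, it is also open whether a group such as methoxy or chloro would behave like cyano or like methyl.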